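Trimethylpyrazinylmethyl Ether Repeated on a Second Amide Core

This account rests on a few compounds, and the source may have more. Where it says the series, first, only, none or still open, it means among the compounds named here.

Of the compounds shown here, three have so far been measured in a functional assay on SH-SY5Y cells (Homo sapiens) for cytotoxicity, read by MTT assay, with stated times of 24 h and 4 h; a lower number here means that less compound is needed, a higher number that more compound is needed for the effect. Compound 1 `COc1cc(CNC(=O)/C=C/c2ccc(OCc3nc(C)c(C)nc3C)c(OC)c2)ccc1O` gives 10200 nM in this assay. Compound 2 `COc1cc(/C=C/C(=O)NCc2ccc(OCc3nc(C)c(C)nc3C)c(OC)c2)ccc1OCc1nc(C)c(C)nc1C` differs from compound 1 by a (3,5,6-trimethylpyrazin-2-yl)methyl in place of hydrogen on an oxygen on an aromatic ring, and in this assay compound 2 gives 11100 nM. That change produced a 1.1-fold higher number from compound 1 to compound 2 (0.04 log units; within the scatter). Compound 3 `COc1ccc(/C=C/C(=O)NCc2ccc(O)c(OC)c2)cc1` rests on a different core; how its core differs from that of compound 1 is not broken down here. In this assay compound 3 gives 11400 nM, a number that lies within the scatter of both compound 1 and compound 2, so the three measured values cannot be placed in any order.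

Compound 4 `COc1ccc(/C=C/C(=O)NCc2ccc(OCc3nc(C)c(C)nc3C)c(OC)c2)cc1` has not been measured yet. It is related to compound 3 by the same change that relates compound 2 to compound 1, namely a (3,5,6-trimethylpyrazin-2-yl)methyl in place of hydrogen on an oxygen on an aromatic ring, and the surroundings of the place are the same in both cases. The step from compound 3 to compound 4 is expected to be a 1.0-fold higher number from compound 3 to compound 4 (0.00 log units; within the scatter) in this assay, because the same change once gave a 1.1-fold higher number from compound 1 to compound 2 (0.04 log units; within the scatter). On that basis compound 4 is estimated at 11500 nM in this assay. The range for compound 4 is expected to run from 6000 nM to 23000 nM.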

Compound 4, half-maximal effective concentration: 5050 nM
The estimate for compound 4 lay 2.3-fold (0.36 log units) above the measured number; the measured number lies below the stated range.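

In this assay, putting (3,5,6-trimethylpyrazin-2-yl)methyl in place of hydrogen on the oxygen of the core of compound 3 gave a 2.3-fold lower number from compound 3 to compound 4 (0.35 log units; beyond the scatter), a modest step, whereas the same change on the core of compound 1 stayed within the scatter, and the two steps cannot be told apart when set side by side: the same change on two cores in this assay, a 1.1-fold higher number (0.04 log units; within the scatter) from compound 1 to compound 2 and a 2.3-fold lower number (0.35 log units; beyond the scatter) from compound 3 to compound 4, 2.5-fold (0.39 log units) apart, within the scatter of two such steps. The series therefore offers no sign that the change behaves differently on the two cores, but two pairs do not establish that its effect is the same on both. Nor do they establish a general lowering of the number, since only the step on the core of compound 3 lies beyond the scatter and the pair of compound 1 and compound 2 goes against such a pattern.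

The compounds shown leave open whether the step on the core of compound 3 depends on the trimethylpyrazine ring itself or would also follow from a simpler group on the same oxygen, such as benzyl or an unsubstituted pyrazinylmethyl. They also leave open how a chain ending in an amine or a carboxylic acid would fare at that place on either core.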